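Triazole to dimethylamino on the propyl chain

The source may report more compounds than this note shows. Statements on the series, on what has been measured and on what is new or still open speak of the compounds shown alone.

In a functional assay on K562 cells (Homo sapiens) for antiproliferative activity, read by MTT assay, with a stated time of 48 h (on this read-out lower numbers stand for stronger inhibition and higher numbers for weaker inhibition), compound 1 (`Cn1cc(C2=C(c3nn(CCCn4cncn4)c4ncccc34)C(=O)NC2=O)c2ccccc21`) gives > 100000 nM, which is a limit of the assay. Compound 2 (`Cn1cc(C2=C(c3nn(CCCn4cncn4)c4ncccc34)C(=O)N(c3ccccc3)C2=O)c2ccccc21`) gives > 100000 nM, also a limit. Among the measured compounds shown here, the position of the series so far is the limit of > 100000 nM in this assay, at which 2 of the 2 values shown sit. For the measured compounds named here, the one measured step is a step that the two limits leave unreadable from compound 1 to compound 2. It concerns the amide-type nitrogen, not the chain, and offers no size to carry over.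

The next change is in the chain: dimethylamino in place of 1H-1,2,4-triazol-1-yl on a saturated chain carbon, three bonds along the chain from an aromatic nitrogen. Compound 3 (`CN(C)CCCn1nc(C2=C(c3cn(C)c4ccccc34)C(=O)N(c3ccccc3)C2=O)c2cccnc21`) thus carries dimethylamino in place of 1H-1,2,4-triazol-1-yl on a saturated chain carbon, three bonds along the chain from an aromatic nitrogen. Going by the values given here, no measured step covers this change, so the size is a judgement and another limit remains possible. The expected change is an at least 3.3-fold lower number from compound 2 to compound 3 (0.52 log units; beyond the scatter), in the direction of stronger inhibition. For compound 3 the estimated value is 30000 nM, with an expected range from 5000 nM to 100000 nM.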

Compound 3, half-maximal inhibitory concentration: 1700 nM
Compound 3: middle estimate off by 18-fold (1.25 log units), on the high side, outside the stated range (below it).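

The chain end is the first place in this series where a change yields a readable number in this assay, while the other compounds remain at the limit: the limit of > 100000 nM in this assay, at which 2 of the 3 values shown sit.

Replacing 3-(1H-1,2,4-triazol-1-yl)propyl with 3-(dimethylamino)propyl gives an at least 58-fold lower number from compound 2 to compound 3 (1.76 log units; beyond the scatter), so this position strongly affects the read-out on the shared core. From the compounds shown here alone, the value of compound 2 is a limit, so the step's true size remains open and the printed size is only a floor.

Open, going by these compounds, is whether another amine, such as pyrrolidin-1-yl or morpholin-4-yl, or a longer chain carrying dimethylamino would hold this activity. Also open is whether the phenyl on the amide-type nitrogen contributes, as the step on that nitrogen cannot be read and no hydrogen counterpart of compound 3 is shown.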